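The source may hold more compounds than are shown below. What is called first, only, known or untested is meant among the compounds shown, and "the series" means these compounds.

In a functional assay (strain AB) with Danio rerio as the target, read by microscopy, with a stated time of 1 h (a higher number here means that more compound is needed for the effect, a lower number that less compound is needed), compound 2 `C[N+]1(CC2CCC2)CCc2c(sc(NC(=O)Nc3ccc(Cl)cc3)c2C(N)=O)C1` gives 210 nM. Going by the values given here, compound 1 `CC(C)(C)OC(=O)CCCCC[N+]1(C)CCc2c(sc(NC(=O)Nc3ccc(Cl)cc3)c2C(N)=O)C1`, the only other compound with a measured number, gives 110 nM, and the two lie within the usual scatter of each other. Compound 3 `CCN1CCc2c(sc(NC(=O)Nc3ccc(Cl)cc3)c2C#N)C1` reads > 25000 nM, which is a limit of the assay and not a number. Among the compounds with values here, no step that changes a single place connects compound 3 with the others, so it offers no guide to the change considered here.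

The next compound is compound 4 `C[N+]1(CC2CCCC2)CCc2c(sc(NC(=O)Nc3ccc(Cl)cc3)c2C(N)=O)C1`, which carries cyclopentyl in place of cyclobutyl on a saturated chain carbon bound to an amine nitrogen in a ring. Put another way, cyclobutylmethyl becomes cyclopentylmethyl.

Within the data shown here, only one measured step bears on this place. It is a 1.9-fold higher number from compound 1 to compound 2 (0.28 log units; within the scatter), and it swaps 4-(tert-butoxycarbonyl)butyl for cyclobutyl. Even that exchange of two quite different groups left this assay within the scatter, so the smaller exchange from cyclobutyl to cyclopentyl is not expected to do more. This rests on a single step, so the expectation is a modest one.

The expected change is a 1.1-fold lower number from compound 2 to compound 4 (0.02 log units; within the scatter), which would be no real step beyond the scatter.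

Compound 4 is estimated at 200 nM, with an expected range of 70 nM to 600 nM.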

Compound 4, half-maximal effective concentration: 200 nM
Estimate against measurement, compound 4: no gap at the digits printed; measured number inside the range.
By their numbers in this assay, from the lowest: compounds 1, 4 and 2 (each within the scatter of the next). At a limit, above all of these: compound 3.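

In this assay, the change of ring size at this place now has a direct reading: a 1.1-fold lower number from compound 2 to compound 4 (0.02 log units; within the scatter). The four-membered and five-membered carbon rings therefore read alike on a saturated chain carbon bound to an amine nitrogen in a ring. The second new step compares the ring with the open chain: a 1.8-fold higher number from compound 1 to compound 4 (0.26 log units; within the scatter), so cyclobutyl, cyclopentyl and 4-(tert-butoxycarbonyl)butyl all lie within the scatter of one another, and this position has so far tolerated three quite different groups without a real shift in the number. Nothing measured in the data shown bears on why these groups read alike.

As far as these compounds go, it remains open whether this tolerance would hold for a chain ending in a free carboxylic acid or an amine, or for a much shorter group such as methyl, since all three groups compared here are large and none carries either of those ends. Compound 3 reads > 25000 nM, which is a limit of the assay, and it differs from the others in more than one place, so it cannot show which single change matters.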